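Triazole aryl swap on the sulfonate ester of compound 1

The compounds below may be only part of what the source reports. "The series", "measured", "known", "first", "only" and "open" are said of these compounds alone.

The shared core carries a triazole bearing either a pyridin-2-yl or a 4-fluorophenyl group. Compound 1 `Cc1ccc(S(=O)(=O)Oc2ccc3c(c2C)[C@H](Cn2cc(-c4ccccn4)nn2)[C@@]24CC(=O)[C@@](C)(CC[C@@H]32)C4)cc1` is the (4-methylphenyl)sulfonyl ester of the phenol. In a functional assay on A549 cells (Homo sapiens) for cytotoxicity, read by MTT assay, with a stated time of 4 days (on this read-out lower numbers stand for stronger inhibition and higher numbers for weaker inhibition), compound 1 gives no number, only the limit > 20000 nM. Compound 2 `Cc1c(O)ccc2c1[C@H](Cn1cc(-c3ccccn3)nn1)[C@@]13CC(=O)[C@@](C)(CC[C@@H]21)C3` is the corresponding free phenol; in this assay compound 2 likewise stops at the limit > 20000 nM. Compound 3 `C=C1C[C@]23C[C@@]1(O)CC[C@H]2c1ccc(O)c(C)c1[C@@H]3Cn1cc(-c2ccc(F)cc2)nn1` places the 4-fluorophenyl triazole on a different core; in this assay compound 3 also returns a limit, > 20000 nM. Compound 1 therefore stands nowhere apart from the rest: every value shown sits at the limit of > 20000 nM in this assay, at which 3 of the 3 values shown sit. Within the data shown here, the single step inside the set, a step that the two limits leave unreadable from compound 1 to compound 2, is unreadable, both of its ends being limits.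

Compound 4 `Cc1ccc(S(=O)(=O)Oc2ccc3c(c2C)[C@H](Cn2cc(-c4ccc(F)cc4)nn2)[C@@]24CC(=O)[C@@](C)(CC[C@@H]32)C4)cc1` keeps the sulfonyl ester of compound 1 and alters only the triazole substituent: 4-fluorophenyl in place of pyridin-2-yl on an aromatic carbon. Among the measured compounds shown here, no measured step covers this swap; the one compound that already carries 4-fluorophenyl, compound 3, sits at the limit like the others. Nothing in the set suggests a step beyond the scatter, so a step that the limit leaves unreadable from compound 1 to compound 4 is expected to be essentially nil. Compound 4 is therefore estimated at 30000 nM, with a range of 10000 nM to 100000 nM, and is most likely to come back again as a limit rather than a number.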

Compound 4, half-maximal inhibitory concentration: > 20000 nM
Compound 4 ended at the assay's limit (the forecaster's own chance of this, stated with the estimate: 85%); the middle value lies beyond the limit too.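

Compound 1 and compound 4 both end at a limit rather than a number, so no step can be read for 4-fluorophenyl in place of pyridin-2-yl. Still open is how these two triazole substituents compare, and whether any change to the compounds shown gives a numerical value in this assay: the limit of > 20000 nM in this assay, at which 4 of the 4 values shown sit.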